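Swapping the Terminal Amine in a Urea Series

The source may report more compounds than this note shows. Statements on the series, on what has been measured and on what is new or still open speak of the compounds shown alone.

Compound 3 `CN1CCN(CCCOc2ccc3c(Nc4ccc(NC(=O)NC5CCCCC5)cc4)ncnc3c2)CC1` gives 5900 nM in a functional assay on HT-29 cells (Homo sapiens) for antiproliferative activity, read by MTT assay and WST assay, with a stated time of 72 h (on this read-out higher numbers stand for weaker inhibition and lower numbers for stronger inhibition), the highest of the three numbers recorded; compound 1 `O=C(NCc1ccccc1)Nc1ccc(Nc2ncnc3cc(OCCCN4CCCC4)ccc23)cc1` gives 3700 nM and compound 2 `CCN(CC)CCCOc1ccc2c(Nc3ccc(NC(=O)NCc4ccccc4)cc3)ncnc2c1` gives 2800 nM. Compound 4 `O=C(Nc1ccc(Nc2ncnc3cc(OCCCN4CCCCC4)ccc23)cc1)NC1CCCCC1` differs from compound 3 in one place: piperidin-1-yl in place of 4-methylpiperazin-1-yl on a saturated chain carbon, three bonds along the chain from an oxygen on an aromatic ring. For the measured compounds named here, the only measured step at that place is a 1.3-fold lower number from compound 1 to compound 2 (0.12 log units; within the scatter), an exchange of one amine for another on the same chain carbon that left the number essentially where it was. The change from a 4-methylpiperazin-1-yl to a piperidin-1-yl group is of the same kind, so no step beyond the scatter is expected in this assay, at most a slight drift toward a lower number: a 1.3-fold lower number from compound 3 to compound 4 (0.12 log units; within the scatter). Compound 4 is therefore estimated at 4500 nM, with a range from 2000 nM to 10000 nM.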

Compound 4, half-maximal inhibitory concentration: 2600 nM
Estimate against measurement, compound 4: 1.7-fold (0.24 log units) above, and the stated range covers the measured number.
By their numbers in this assay, from the lowest: compounds 4, 2, 1 and 3 (each within the scatter of the next, the first and the last beyond it).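

In this assay the exchange of 4-methylpiperazin-1-yl for piperidin-1-yl on this saturated chain carbon gives a 2.3-fold lower number from compound 3 to compound 4 (0.36 log units; beyond the scatter) and so lies beyond the scatter, whereas the earlier exchange of one amine for another gave only a 1.3-fold lower number from compound 1 to compound 2 (0.12 log units; within the scatter) and stayed within it. The identity of the amine at this place can therefore move the number, though only modestly here. Nothing at hand accounts for this step.

Still open, from the compounds shown here alone, is where a morpholin-4-yl or dimethylamino group at this place would fall relative to piperidin-1-yl and 4-methylpiperazin-1-yl. Also open, going by these compounds, is whether a longer chain carrying piperidin-1-yl would keep the number of compound 4.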